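The source may hold more compounds than are shown below. What is called first, only, known or untested is meant among the compounds shown, and "the series" means these compounds.

Measured in a physicochemical assay for solubility; on this read-out lower numbers stand for lower solubility and higher numbers for higher solubility:
- Compound 1 `CNC(=O)c1cc(C(=O)NC2CC2)cn(Cc2ccc(F)cc2)c1=O`: >= 162 ug/mL
- Compound 2 `CNC(=O)c1cc(C(=O)NC2CC2)cn([C@H](C)c2ccccc2)c1=O`: >= 168 ug/mL
- Compound 3 `CNC(=O)c1cc(C(=O)NC2CC2)cn(Cc2cccc([C@@H](C)O)c2)c1=O`: >= 131 ug/mL

All three readings are limits of the assay and not exact numbers. Compound 3 therefore stands only at its limit of >= 131 ug/mL, and no exact place can be given for it among the others.

The next compound is compound 4 `CNC(=O)c1cc(C(=O)NC2CC2)cn(Cc2ccccc2F)c1=O`, which puts 2-fluorophenyl in place of 3-(1-hydroxyethyl)phenyl on a saturated chain carbon bound to an aromatic nitrogen.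

Going by the values given here, two measured steps bear on this. The closer one is a step that the two limits leave unreadable from compound 1 to compound 3, which placed 3-(1-hydroxyethyl)phenyl where compound 1 has 4-fluorophenyl. The other is a step that the two limits leave unreadable from compound 1 to compound 2, a change on the aromatic nitrogen. Neither size can be read, so they give no direction, and no step beyond the usual scatter is expected in this assay. The expected change is a step that the limit leaves unreadable from compound 3 to compound 4. Compound 4 is estimated at 150 ug/mL, with an expected range from 90 ug/mL to 250 ug/mL.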

Compound 4, solubility: >= 145 ug/mL
Compound 4: only a limit was reported; the forecaster's own chance of this, stated with the estimate: 75%; the middle value does not contradict the limit.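

Compound 4, like compounds 1, 2 and 3, is reported in this assay only as a limit and not as an exact number, so no step among these four compounds can be read. The compounds shown leave open whether changing the group on the aromatic nitrogen shifts this read-out at all, and by how much.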